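Sulfur substituents in the series: the step to compound 4

The compounds below may be only part of what the source reports. "The series", "measured", "known", "first", "only" and "open" are said of these compounds alone.

Values in a functional assay on HCT-116 cells (Homo sapiens) for inhibition, read by MTT assay, with a stated time of 48 h; on this read-out higher numbers stand for weaker inhibition and lower numbers for stronger inhibition:
compound 1 `COc1ccc(-n2c(S)nnc2-c2cc(OC)c(OC)c(OC)c2)cc1`: > 60000 nM (a limit)
compound 2 `CCSc1nnc(-c2cc(OC)c(OC)c(OC)c2)n1-c1ccc(OC)cc1`: > 60000 nM (a limit)
compound 3 `COc1ccc(CSc2nnc(-c3cc(OC)c(OC)c(OC)c3)n2-c2ccc(OC)cc2)cc1`: 49600 nM

Compound 2 stands at the limit of > 60000 nM in this assay, at which 2 of the 3 values shown sit, which is a limit and not a number. Compound 4 `COc1ccc(-n2c(SCC(=O)c3ccccc3)nnc2-c2cc(OC)c(OC)c(OC)c2)cc1` carries benzoyl in place of the methyl of compound 2, on a saturated chain carbon bound to a sulfur: benzoyl in place of methyl on a saturated chain carbon bound to a sulfur.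

The closest measured change is an at least 1.2-fold lower number from compound 2 to compound 3 (0.08 log units; that floor lies within the scatter), with 4-methoxyphenyl entering at that same place. The change an at least 1.2-fold lower number from compound 1 to compound 3 (0.08 log units; that floor lies within the scatter) bears on it too, whereas a step that the two limits leave unreadable from compound 1 to compound 2 gives no size. Both readable steps are small, so only a small move to a lower number is expected, possibly none beyond the scatter. The expected step is an at least 1.3-fold lower number from compound 2 to compound 4 (0.12 log units; that floor lies within the scatter). For compound 4 the estimate is 45000 nM, with an expected range of 20000 nM to 90000 nM.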

Compound 4, half-maximal inhibitory concentration: > 60000 nM
Compound 4 was reported as a limit; the forecaster's own chance of this, stated with the estimate: 45%; middle value at least 1.3-fold (0.12 log units) away from the limit.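

In this assay compound 4 is reported only as a limit, so a six-membered aromatic ring on the saturated chain carbon bound to a sulfur does not by itself yield a readable value: the limit of > 60000 nM in this assay, at which 3 of the 4 values shown sit. Within the data shown here, the one readable step is an at least 1.2-fold higher number from compound 3 to compound 4 (0.08 log units; that floor lies within the scatter) and sets no firm gap; the steps from compound 1 and from compound 2 to compound 4 cannot be read.

Still open, as far as these compounds go, is whether an unsubstituted benzyl on the sulfur gives a number. An amine or carboxylic acid at this chain carbon is equally untested in the compounds shown.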